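The source may hold more compounds than are shown below. What is called first, only, known or untested is meant among the compounds shown, and "the series" means these compounds.

Measured so far:
- compound 1, `COc1ccc(/C=C2\C(=O)N(c3c(Cl)cccc3Cl)c3ccccc32)cc1OC`: > 100 ug/mL (a limit of the assay)
- compound 2, `O=C1/C(=C\c2ccc(F)cc2)c2ccccc2N1c1c(Cl)cccc1Cl`: 13 ug/mL
- compound 3, `CN(C)c1ccc(/C=C2\C(=O)N(c3c(Cl)cccc3Cl)c3ccccc32)cc1`: > 100 ug/mL (a limit of the assay)

In a functional assay on L132 cells (Homo sapiens) for cytotoxicity, read by MTT assay, with a stated time of 72 h (on this read-out higher numbers stand for an effect only at larger amounts of compound and lower numbers for an effect already at smaller amounts), compound 2 gives 13 ug/mL. Compound 3 gives no number, only the limit > 100 ug/mL. Compound 1 likewise gives only the limit > 100 ug/mL. Compound 3 therefore stands at the limit of > 100 ug/mL in this assay, at which 2 of the 3 values shown sit, and two of the three compounds measured sit there.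

For the measured compounds named here, the only single change measured so far is an at least 7.6-fold higher number from compound 2 to compound 3 (0.88 log units; beyond the scatter). Because compound 3 ends at a limit, that step can only be given as a lower bound.

Compound 4, `COc1ccc(/C=C2\C(=O)N(c3c(Cl)cccc3Cl)c3ccccc32)cc1`, has not yet been measured. It differs from compound 3 by methoxy in place of dimethylamino on an aromatic carbon. Going by the values given here, no measured step covers exactly this change. The nearest guide is compound 1, which carries a methoxy on the same ring and sits at the limit, the same as compound 3. On that basis, the step from compound 3 to compound 4 is expected to be a number no higher from compound 3 to compound 4 (the limit leaves the size open), which is no change beyond the scatter, with compound 4 most likely also reported only as a limit. Compound 4 is thus expected to give about 100 ug/mL in this assay, somewhere between 30 ug/mL and 300 ug/mL.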

Compound 4, concentration for half-maximal effect: > 100 ug/mL
Compound 4: only a limit was reported; the forecaster's own chance of this, stated with the estimate: 70%; the middle value sits exactly at the limit.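

In this assay, for the compounds shown here, the new result shows that dimethylamino is not the only group at this place on the ring that moves the compound away from the one measured number: methoxy in place of fluoro gives an at least 7.6-fold higher number from compound 2 to compound 4 (0.88 log units; beyond the scatter), a step that matches in its lower bound the one seen with dimethylamino, an at least 7.6-fold higher number from compound 2 to compound 3 (0.88 log units; beyond the scatter). The steps linking compound 1, compound 3 and compound 4 cannot be read, as each of these compounds ends at a limit of the assay and not at a number, so no order among them can be stated. Compound 2, with its fluoro, is now the single compound that stands apart from the others and gives a real number: the limit of > 100 ug/mL in this assay, at which 3 of the 4 values shown sit.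

The compounds shown leave open how far past the limit compound 1, compound 3 and compound 4 really lie, and so whether methoxy and dimethylamino differ at all on these cells. They also leave open whether the number of compound 2 is special to fluoro, which a nitrile or a trifluoromethyl at the same place on the ring could test.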